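The source may hold more compounds than are shown below. What is called first, only, known or untested is meant among the compounds shown, and "the series" means these compounds.

Measured in a physicochemical assay for solubility, in phosphate buffer, at pH 7.4; a higher number here means a more soluble compound, a lower number a less soluble compound:
- compound 1 `c1ccc2nc(N3CC(Oc4nccnc4N4CCCCC4)C3)ccc2c1`: < 1000 nM (a limit)
- compound 2 `c1ccc2nc(N3CC(Oc4nccnc4-c4cccc5ncccc45)C3)ccc2c1`: 47000 nM

For the measured compounds named here, compound 2 stands at 47000 nM as the only actual number so far. Compound 1 sits at < 1000 nM and this is a limit of the assay. Compound 3 `CS(=O)(=O)N1CCC(c2nccnc2OC2CN(c3ccc4ccccc4n3)C2)CC1` differs from compound 2 by 1-(methylsulfonyl)piperidin-4-yl in place of quinolin-5-yl on an aromatic carbon. Going by the values given here, the one measured step at this place is an at least 47-fold higher number from compound 1 to compound 2 (1.67 log units; beyond the scatter) and it is large, with quinolin-5-yl in place of piperidin-1-yl. Compound 3 again carries a six-membered non-aromatic ring there, so a clear drop in this assay is expected, though perhaps a smaller one. The expected change is a 5.9-fold lower number from compound 2 to compound 3 (0.77 log units; beyond the scatter) by this estimate. For compound 3 the estimate is 8000 nM, with an expected range of 1500 nM to 40000 nM for now.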

Compound 3, solubility: 181000 nM
Compound 3: the middle estimate sits 23-fold (1.35 log units) below what was measured; the whole stated range lies below it.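

In this assay, this place on the aromatic carbon does not need an aromatic group for a high number: 1-(methylsulfonyl)piperidin-4-yl gives a 3.9-fold higher number from compound 2 to compound 3 (0.59 log units; beyond the scatter). Against piperidin-1-yl the same group gives an at least 180-fold higher number from compound 1 to compound 3 (2.25 log units; beyond the scatter), so a six-membered non-aromatic ring as such does not fix the number here. That step rests on a limit for compound 1, not a number: the limit of < 1000 nM in this assay, at which 1 of the 3 values shown sits.

Whether the methylsulfonyl group or the attachment as piperidin-4-yl rather than piperidin-1-yl accounts for the difference stays open. A plain piperidin-4-yl, or an acetyl on its nitrogen, would separate the two.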